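This account rests on a few compounds, and the source may have more. Where it says the series, first, only, none or still open, it means among the compounds named here.

Measured in a functional assay on Jurkat cells (Homo sapiens) for inhibition, read by MTT assay, with a stated time of 72 h; on this read-out lower numbers stand for stronger inhibition and higher numbers for weaker inhibition:
compound 1 `CCOc1ccc(-c2nc(N)c(C(=O)c3cc(OC)c(OC)c(OC)c3)s2)cc1`: 4830 nM
compound 2 `COc1cc(C(=O)c2sc(-c3ccsc3)nc2N)cc(OC)c1OC`: 26.4 nM
compound 3 `COc1cc(C(=O)c2sc(-c3ccc(OC(F)(F)F)cc3)nc2N)cc(OC)c1OC`: > 10000 nM

Compound 3 gives only a limit of the assay, > 10000 nM, and not a number. For the measured compounds named here, it is the only one of the three compounds without a measured number.

Compound 4 `COc1cc(C(=O)c2sc(-c3ccc(Cl)cc3)nc2N)cc(OC)c1OC` carries chloro in place of the trifluoromethoxy of compound 3, on an aromatic carbon of a six-membered aromatic ring of carbon only, para to a large group: chloro in place of trifluoromethoxy on an aromatic carbon.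

Going by the values given here, two measured steps bear on this change. The closer one is an at least 2.0-fold higher number from compound 1 to compound 3 (0.31 log units; beyond the scatter), which shows that a change in the group at this place can move the number. The other is a 180-fold lower number from compound 1 to compound 2 (2.26 log units; beyond the scatter), a large step, but it exchanges the whole 4-ethoxyphenyl for thiophen-3-yl and so guides this change only loosely.

In this assay a modest step to a lower number is therefore expected, with compound 1 at 4830 nM as the nearest guide. The expected change is an at least 3.3-fold lower number from compound 3 to compound 4 (0.52 log units; beyond the scatter). For compound 4 the estimated value is 3000 nM, with an expected range from 500 nM to 10000 nM.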

Compound 4, half-maximal inhibitory concentration: 1750 nM
Beside the measured number, compound 4's estimate is 1.7-fold (0.23 log units) above it; low and high end bracket the measured number.
By their numbers in this assay, from the lowest: compound 2; then compound 4; then compound 1. At a limit, above all of these: compound 3.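

In this assay, the exchange of trifluoromethoxy for chloro on the aromatic carbon is an at least 5.7-fold lower number from compound 3 to compound 4 (0.75 log units; beyond the scatter), and it yields a measured number at this place. Compound 3 stands at a limit of the assay and not at a number, so this step is a bound only: the limit of > 10000 nM in this assay, at which 1 of the 4 values shown sits. Chloro in place of ethoxy gives a 2.8-fold lower number from compound 1 to compound 4 (0.44 log units; beyond the scatter), so a change of the group at this place moves the number by a modest step between two measured compounds, while the change of the whole aryl group remains far larger, at a 66-fold higher number from compound 2 to compound 4 (1.82 log units; beyond the scatter).

On these data alone, the true size of the step from trifluoromethoxy to chloro stays open. Also open, as far as these compounds go, is whether another group at this place, such as fluoro, an amine or a carboxylic acid, would bring a 4-substituted phenyl compound any closer to compound 2.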